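The source may report more compounds than this note shows. Statements on the series, on what has been measured and on what is new or still open speak of the compounds shown alone.

Compound 2 `CCNc1nc(Cl)nc(N[C@H](C)c2ccccc2)n1`, compound 1 `C[C@H](Nc1nc(Cl)nc(NC(C)(C)C)n1)c1ccccc1` and compound 3 `CC(C)Nc1nc(Cl)nc(N[C@@H](C)c2ccccc2)n1` share one core and differ only in the branching of the alkylamino arm. In an ADME assay on the whole organism for inhibition, with Oryza sativa as the target, with a stated time of 4 days (a higher number here means a weaker inhibitor, a lower number a stronger inhibitor), compound 2 gives 14100 nM, the second highest of the three numbers; compound 3 gives 23400 nM, within the scatter of compound 2, while compound 1 gives 3310 nM, a lower number beyond the scatter. Compound 4 `CC[C@@H](C)Nc1nc(Cl)nc(N[C@H](C)c2ccccc2)n1` differs from compound 2 by ethyl in place of hydrogen on a saturated chain carbon bound to a nitrogen on an aromatic ring and a saturated chain carbon. Among the measured compounds shown here, the one step that bears on adding alkyl on that arm runs the other way: a 7.1-fold higher number from compound 1 to compound 3 (0.85 log units; beyond the scatter). So adding a chain is expected to lower the number for compound 4, estimated at 4000 nM (range 1500 nM to 12000 nM), a step of a 3.5-fold lower number from compound 2 to compound 4 (0.55 log units; beyond the scatter).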

Compound 4, half-maximal inhibitory concentration: 8320 nM
Compound 4: the middle estimate sits 2.1-fold (0.32 log units) below what was measured; the measured number falls inside the stated range.
By their numbers in this assay, from the lowest: compound 1; then compounds 4, 2 and 3 (each within the scatter of the next, the first and the last beyond it).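

In this assay, ethyl in place of hydrogen on this saturated chain carbon gives a 1.7-fold lower number from compound 2 to compound 4 (0.23 log units; within the scatter), so going from ethylamino to (sec-butyl)amino does not separate the two compounds. The other step on this arm, a 7.1-fold higher number from compound 1 to compound 3 (0.85 log units; beyond the scatter), lies beyond the scatter, so not every change of branching here reaches that size. No evidence bears on the reason for this difference between the two steps. The compounds shown leave open whether a longer chain, such as hexyl, or a hydroxyl on this arm would move the number beyond the scatter.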